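A few compounds are considered here, and "the series" means these few. Any claim that something is new, unique, unknown or untested is made for them only; others in the source may bear on it.

Compound 1, with the structure `Cn1c(-c2ccc(NC(=O)CCl)cc2)nc(-c2ccccc2)c1-c1ccccc1`, gives 42.6 ug/mL in a functional assay on MCF7 cells (Homo sapiens) for cytotoxicity, read by MTT assay, with a stated time of 24 h; on this read-out higher numbers stand for weaker inhibition and lower numbers for stronger inhibition.
Compound 2, with the structure `Cn1c(-c2ccc(NC(=O)CSc3nc4ccccc4o3)cc2)nc(-c2ccccc2)c1-c1ccccc1`, gives 11.2 ug/mL in this assay.

Of these two numbers compound 2 holds the lower one; its nearest neighbour is compound 1, separated by the step of a 3.8-fold lower number from compound 1 to compound 2 (0.58 log units; beyond the scatter), which exchanged the group on the saturated chain carbon bound to the carbonyl carbon.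

Compound 3, with the structure `Cn1c(-c2ccc(NC(=O)CSc3nc4cc(Cl)ccc4o3)cc2)nc(-c2ccccc2)c1-c1ccccc1`, has not yet been measured. It differs from compound 2 by chloro in place of hydrogen on an aromatic carbon. Within the data shown here, no measured step touches a substituent on that fused ring: the single step recorded concerns a different part of the molecule, so it offers no guide to the direction or size of this change. The expectation is therefore a step of a 1.2-fold lower number from compound 2 to compound 3 (0.07 log units; within the scatter) in this assay, that is, nothing beyond the usual scatter. Compound 3 is estimated at 9.5 ug/mL, with a range from 4 ug/mL to 25 ug/mL.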

Compound 3, half-maximal inhibitory concentration: 21.7 ug/mL
Compound 3: the middle estimate sits 2.3-fold (0.36 log units) below what was measured; measured number inside the range.
By their numbers in this assay, from the lowest: compounds 2, 3 and 1 (each within the scatter of the next, the first and the last beyond it).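

In this assay, among these compounds, chloro on the six-membered aromatic ring of the 1,3-benzoxazol-2-yl group gives a 1.9-fold higher number from compound 2 to compound 3 (0.29 log units; within the scatter) and so offers the first reading at this position, one that cannot be told apart from repeat-measurement noise. The exchange on the chain carbon also reads differently with this chlorinated group: the unsubstituted group gave a 3.8-fold lower number from compound 1 to compound 2 (0.58 log units; beyond the scatter) while the 5-chloro-1,3-benzoxazol-2-yl group gives a 2.0-fold lower number from compound 1 to compound 3 (0.29 log units; within the scatter) and no longer stands clear of the scatter. No measurement available here bears on why these numbers fall as they do.

Going by these compounds, whether a methoxy group or an amine in place of this chloro would move the number beyond the scatter remains open. So does whether a longer chain carrying the (5-chloro-1,3-benzoxazol-2-yl)sulfanyl group would read differently.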